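This account rests on a few compounds, and the source may have more. Where it says the series, first, only, none or still open, it means among the compounds named here.

In a toxicity assay on THP-1 cells (Homo sapiens) for inhibition (on this read-out lower numbers stand for higher toxicity in this test and higher numbers for lower toxicity in this test), three compounds that share one core have been tested so far. Compound 1 `Cn1c(-c2ccccc2F)cnc1NC(=O)c1ccc(F)cc1` gives > 100000 nM, which is a limit of the assay and not a number. Among the compounds with values here, compound 2 `Cn1c(-c2ccc(Br)cc2)cnc1NC(=O)c1ccc(F)cc1` gives 46000 nM, the only true number in the set. As far as these compounds go, compound 3 `Cn1c(-c2ccccc2Cl)cnc1NC(=O)c1ccc(F)cc1` gives > 50000 nM, again only a limit, so its exact standing is unknown. Compound 4 `COc1cccc(-c2cnc(NC(=O)c3ccc(F)cc3)n2C)c1` carries 3-methoxyphenyl in place of 2-chlorophenyl on an aromatic carbon. Within the data shown here, three measured steps bear on this change, all of them swaps on the same aromatic carbon or on its phenyl group. The first is an at least 2.1-fold lower number from compound 1 to compound 2 (0.33 log units; beyond the scatter), a modest step. The second is an at least 1.0-fold higher number from compound 2 to compound 3 (0.03 log units; that floor lies within the scatter), whose floor tells little. The third is a step that the two limits leave unreadable from compound 1 to compound 3, and its size cannot be read. None of them involves 3-methoxyphenyl, so only a small change is expected in this assay, with no clear direction. The expected step is a step that the limit leaves unreadable from compound 3 to compound 4. The estimate for compound 4 is 60000 nM, within an expected range from 25000 nM to 130000 nM.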

Compound 4, half-maximal cytotoxic concentration: > 100000 nM
Compound 4 was reported as a limit; the forecaster's own chance of this, stated with the estimate: 50%; middle value at least 1.6-fold (0.22 log units) away from the limit.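

In this assay, within the data shown here, compound 4 brings the first phenyl group at this position that carries an oxygen and a hydrogen-bond acceptor, and its result is a limit of the assay and not a number. Among these compounds, the one readable comparison is an at least 2.1-fold higher number from compound 2 to compound 4 (0.33 log units; beyond the scatter), so 4-bromophenyl now stands apart from 3-methoxyphenyl as well as from 2-fluorophenyl, with compound 2 still the only compound that has a true number. The steps to compound 4 from compound 3 and from compound 1 cannot be read, because both ends of each are limits: the limit of > 100000 nM in this assay, at which 2 of the 4 values shown sit.

As far as these compounds go, how far compound 1, compound 3 and compound 4 truly lie from one another remains open. Also open, from the compounds shown here alone, is how an amine or a carboxylic acid on this phenyl ring, or a longer chain in place of the methoxy group, would read in this assay.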